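Methoxy for Methyl: Expected Cytotoxicity of Compound 4

The compounds below may be only part of what the source reports. "The series", "measured", "known", "first", "only" and "open" are said of these compounds alone.

Compound 1 `CN1CCN(CC(=O)Nc2ccc(-c3nc(-c4ccccc4)c(-c4ccccc4)n3C)cc2)CC1` gives 1.1% in a functional assay on MCF7 cells (Homo sapiens) for cytotoxicity, read by MTT assay, with a stated time of 24 h, tested at 0.64 ug/mL; a higher number here means a stronger effect of the compound at the concentration tested, a lower number a weaker effect.
Compound 2 `CN(C)/C=C/N1CCN(CC(=O)Nc2ccc(-c3nc(-c4ccccc4)c(-c4ccccc4)n3C)cc2)CC1` gives 1.2% in this assay.
Compound 3 `Cc1ccc(CN2CCN(CC(=O)Nc3ccc(-c4nc(-c5ccccc5)c(-c5ccccc5)n4C)cc3)CC2)cc1` gives 9.4% in this assay.

All three share the same core and differ only in what sits on the amine nitrogen in the ring. Compound 3 carries the top number of the three, yet it is not separated from the others: a number 8.3 percentage points higher from compound 1 to compound 3 (within the scatter) and a number 8.2 percentage points higher from compound 2 to compound 3 (within the scatter) both lie within the scatter, as does a number 0.1 percentage points higher from compound 1 to compound 2 (within the scatter). In short, every measured change has left the read-out where it was.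

Within the data shown here, compound 4 `COc1ccc(CN2CCN(CC(=O)Nc3ccc(-c4nc(-c5ccccc5)c(-c5ccccc5)n4C)cc3)CC2)cc1` is the next step from compound 3. methoxy in place of methyl on an aromatic carbon The change sits on the ring attached to that nitrogen, a position no measured step has touched, so none of the three steps bears directly on it. What they do show is that swapping groups at this end of the molecule has so far made no difference beyond the scatter. On that basis, compound 4 is expected to behave like compound 3, with an estimated step of a number 0.4 percentage points lower from compound 3 to compound 4 (within the scatter) in this assay. The value estimated for compound 4 is 9%, within a range from 0% to 25%.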

Compound 4, a percentage reported as activity, at one concentration (the size of the read-out at that concentration, not a potency): 1%
Beside the measured number, compound 4's estimate is 8 percentage points above it, and the stated range covers the measured number.
By their numbers in this assay, from the lowest: compounds 4, 1, 2 and 3 (each within the scatter of the next).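

Among these compounds, this is the first measured step on the aromatic ring carried by the benzyl group, and in this assay it reads (a number 8.4 percentage points lower from compound 3 to compound 4 (within the scatter)). Methoxy in place of methyl on this aromatic carbon, para to a large group, therefore leaves the read-out within the usual scatter, even though the added oxygen brings one hydrogen-bond acceptor that the methyl lacks. The other two comparisons, (a number 0.2 percentage points lower from compound 2 to compound 4 (within the scatter)) and (a number 0.1 percentage points lower from compound 1 to compound 4 (within the scatter)), also stay within the scatter, and no measurement shown here offers an explanation for any of these numbers.

As far as these compounds go, all four compounds remain within the scatter of one another at a single tested concentration, so it remains open whether any group on this ring can separate one compound from another in this read-out. A chlorine atom, a carboxylic acid or an amine on the same aromatic carbon, or a longer chain such as ethoxy, would test this position with groups unlike the methyl and methoxy compared here.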